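This account rests on a few compounds, and the source may have more. Where it says the series, first, only, none or still open, it means among the compounds named here.

Compound 1 `C=CC(=O)Nc1cccc(-c2nc3ccccc3s2)c1` gives 180 nM in a physicochemical assay for solubility, in phosphate buffer, measured as kinetic solubility, with a stated time of 18 h, at pH 7.4; a higher number here means a more soluble compound, a lower number a less soluble compound.
Compound 2 `CC(Cl)C(=O)Nc1cccc(-c2nc3ccccc3s2)c1` gives 830 nM.
Compound 3 `O=C(Nc1cccc(-c2nc3ccccc3s2)c1)c1cccnc1Cl` gives 520 nM.

Of these three numbers compound 3 holds the second highest: it lies within the scatter of compound 2 (a 1.6-fold lower number from compound 2 to compound 3 (0.20 log units; within the scatter)) and beyond the scatter above compound 1 (a 2.9-fold higher number from compound 1 to compound 3 (0.46 log units; beyond the scatter)). Compound 4 `O=C(Nc1cccc(-c2nc3ccccc3s2)c1)c1ccncc1Cl` has not been measured. It differs from compound 3 in one place: 3-chloropyridin-4-yl in place of 2-chloropyridin-3-yl on a carbonyl carbon. Among the measured compounds shown here, no measured step swaps one chloropyridinyl group for another; the nearest guide is a 1.6-fold lower number from compound 2 to compound 3 (0.20 log units; within the scatter), which stayed within the scatter, while a 4.6-fold higher number from compound 1 to compound 2 (0.66 log units; beyond the scatter) and a 2.9-fold higher number from compound 1 to compound 3 (0.46 log units; beyond the scatter) both show modest rises from the smallest group. On that guide compound 4 is expected to show no step beyond the scatter: a 1.0-fold lower number from compound 3 to compound 4 (0.02 log units; within the scatter). The estimate for compound 4 is 500 nM, ranging from 200 nM to 1300 nM.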

Compound 4, solubility: 320 nM
Compound 4: the middle estimate sits 1.6-fold (0.19 log units) above what was measured, within the range that was stated.
By their numbers in this assay, from the lowest: compounds 1, 4, 3 and 2 (each within the scatter of the next, the first and the last beyond it).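

In this assay, among the compounds shown here, the first swap of one chloropyridinyl group for another on this carbonyl carbon, with the same atoms joined differently, shows no real shift (a 1.6-fold lower number from compound 3 to compound 4 (0.21 log units; within the scatter)). Yet 3-chloropyridin-4-yl stays within the scatter of vinyl (a 1.8-fold higher number from compound 1 to compound 4 (0.25 log units; within the scatter)), which 2-chloropyridin-3-yl did not. It also falls beyond the scatter of 1-chloroethyl (a 2.6-fold lower number from compound 2 to compound 4 (0.41 log units; beyond the scatter)), which 2-chloropyridin-3-yl likewise did not.

From the compounds shown here alone, how an amine or a carboxylic acid on this carbonyl carbon would read remains open. Nothing available explains any of these steps.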